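Removing One Methoxy from a Dimethoxyphenyl Quinoxaline

This account rests on a few compounds, and the source may have more. Where it says the series, first, only, none or still open, it means among the compounds named here.

Compound 1 `COc1ccc(CNc2nc3cc(N)cc(N)c3nc2-c2ccccc2)cc1OC` gives 58900 nM in a functional assay on SF-295 cells (Homo sapiens) for inhibition, read by sulforhodamine B assay, with a stated time of 48 h; on this read-out higher numbers stand for lower toxicity in this test and lower numbers for higher toxicity in this test.
Compound 2 `COc1cc(CNc2nc3cc(N)cc(N)c3nc2-c2ccccc2)cc(OC)c1OC` gives 37200 nM in this assay.

Among the compounds with values here, compound 1 stands at the higher of the two numbers; the only step recorded, a 1.6-fold lower number from compound 1 to compound 2 (0.20 log units; within the scatter), adds a methoxy and is within the scatter. Compound 3 `COc1ccc(CNc2nc3cc(N)cc(N)c3nc2-c2ccccc2)cc1` differs from compound 1 by hydrogen in place of methoxy on an aromatic carbon, so the wording in this pair reads 3,4-dimethoxyphenyl to 4-methoxyphenyl. Within the data shown here, since the sole related step was within the scatter, no step beyond the scatter is expected in this assay either; the estimated step from compound 1 to compound 3 is a 1.2-fold higher number from compound 1 to compound 3 (0.07 log units; within the scatter). Compound 3 is thus expected to give about 70000 nM, between 30000 nM and 160000 nM.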

Compound 3, concentration lethal to 50% of the cells: 58900 nM
For compound 3 the middle estimate is 1.2-fold (0.07 log units) above the measured one; the range from low to high includes it.
By their numbers in this assay, from the lowest: compounds 2, 1 and 3 (each within the scatter of the next).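

In this assay, hydrogen in place of the methoxy gives no change at the digits printed from compound 1 to compound 3 (within the scatter), so this position of the 3,4-dimethoxyphenyl group can lose its methoxy with no step beyond the scatter. Compound 2 showed only an added methoxy, with a 1.6-fold lower number from compound 1 to compound 2 (0.20 log units; within the scatter); the number has now been read with one methoxy more and one fewer, and neither step leaves the scatter. Nothing available explains this result.

From the compounds shown here alone, whether an amine or a carboxylic acid at this position would move the number beyond the scatter stays open. So does the effect of replacing the methoxy that remains in compound 3.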